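The compounds below may be only part of what the source reports. "The series", "measured", "known", "first", "only" and "open" are said of these compounds alone.

Measured compounds:
- compound 1, `CC(=O)c1ccc(NC(=O)C(CC(C)C)N(C(=O)c2ccccc2)S(=O)(=O)c2ccc(C)cc2)cc1`: 71.3%
- compound 2, `CCC(C)C(C(=O)Nc1ccc(C(C)=O)cc1)N(C(=O)c1ccccc1)S(=O)(=O)c1ccc(C)cc1`: 47.3%
- compound 3, `CC(=O)c1ccc(NC(=O)C(CC(C)C)N(C(=O)c2ccccc2)S(=O)(=O)c2ccccc2)cc1`: 52.2%

All three numbers come from a functional assay for inhibition, read by spectrophotometry, with a stated time of 20 min, tested at 5 mg/mL; on this read-out higher numbers stand for a stronger effect at the one concentration tested and lower numbers for a weaker effect. Two single changes start from compound 1. The first, (sec-butyl in place of isobutyl on a saturated chain carbon bound to an amide-type nitrogen and a carbonyl carbon), gives the step of a number 24 percentage points lower from compound 1 to compound 2 (beyond the scatter). The second, (hydrogen in place of methyl on an aromatic carbon), gives the step of a number 19.1 percentage points lower from compound 1 to compound 3 (beyond the scatter). The values of compound 2 and compound 3 lie within the scatter of each other, so nothing is drawn from that pair.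

Compound 4, `CCC(C)C(C(=O)Nc1ccc(C(C)=O)cc1)N(C(=O)c1ccccc1)S(=O)(=O)c1ccccc1`, is not yet measured in this assay. It differs from compound 3 by sec-butyl in place of isobutyl on a saturated chain carbon bound to an amide-type nitrogen and a carbonyl carbon. The two cores differ by hydrogen in place of methyl on an aromatic carbon. For the measured compounds named here, the change from compound 3 to compound 4 is the same as the one already measured from compound 1 to compound 2: the place is the same in both cases, and the group that leaves and the group that enters are the same. Among the compounds here this change occurs twice in all, and only once with a measured outcome, so the expectation rests on a single step.

Going by the values given here, for compound 4 the step is expected to be a number 22.2 percentage points lower from compound 3 to compound 4 (beyond the scatter), set close to the earlier one because a number 24 percentage points lower from compound 1 to compound 2 (beyond the scatter) is the only observed example of this change and there is no reason within these three compounds to expect a different size on the other core. The number for compound 4 in this assay is accordingly estimated at 30%, with a range from 12% to 48% that allows for the scatter of this kind of measurement and for the change behaving somewhat differently on the core of compound 3.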

Compound 4, a percentage reported as inhibition, at one concentration (the size of the read-out at that concentration, not a potency): 16.8%
For compound 4 the middle estimate is 13.2 percentage points above the measured one, and the stated range covers the measured number.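

In this assay, sec-butyl in place of isobutyl on the core of compound 3 gives a number 35.4 percentage points lower from compound 3 to compound 4 (beyond the scatter), and the same change on the core of compound 1 stands close to it: the same change on two cores in this assay, a number 24 percentage points lower (beyond the scatter) from compound 1 to compound 2 and a number 35.4 percentage points lower (beyond the scatter) from compound 3 to compound 4, 11.4 percentage points apart, within the scatter of two such steps

Hydrogen in place of methyl on an aromatic carbon, read on the sec-butyl core, gives a number 30.5 percentage points lower from compound 2 to compound 4 (beyond the scatter), and this too agrees with the step on the isobutyl core: the same change on two cores in this assay, a number 19.1 percentage points lower (beyond the scatter) from compound 1 to compound 3 and a number 30.5 percentage points lower (beyond the scatter) from compound 2 to compound 4, 11.4 percentage points apart, within the scatter of two such steps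

Each change therefore carries between these two cores in direction and, within the scatter, in size, but the two comparisons draw on the same four values and so count as one observation, which does not show that either change would carry to any other core or that the size would hold at another concentration.

Open, as far as these compounds go, is whether a longer chain or a cyclohexyl group on the saturated chain carbon would continue the same trend, and whether the drop follows the sec-butyl group specifically or any chain of another shape. Also open, from the compounds shown here alone, is how chloro or methoxy in place of methyl on the aromatic carbon would compare with the methyl and hydrogen pair on either core.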